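Swapping Ethyl for Oxan-4-yl on the Aromatic Oxygen

The source may report more compounds than this note shows. Statements on the series, on what has been measured and on what is new or still open speak of the compounds shown alone.

Compound 3 `CCOc1nc(-c2ccc(NS(=O)(=O)c3cc(Cl)ccc3F)cc2)nc2[nH]nc(C)c12` is the only one of the three measured compounds reported with a number rather than a limit. In an assay for inhibition of serine/threonine-protein kinase Sgk1 (Homo sapiens), with stated times of 30 min and 60 min, in the presence of a further agent that is not named here (on this read-out higher numbers stand for weaker inhibition and lower numbers for stronger inhibition), compound 3 gives 23 nM. Compound 1 `CN1CC(NC(=O)c2cc(-c3ccc(NS(=O)(=O)c4cccc(Cl)c4Cl)cc3)nc3[nH]ncc23)C1` is reported in this assay only as a limit, < 1 nM. Compound 2 `CCN1CCC(CNC(=O)c2cc(-c3ccc(NS(=O)(=O)c4cccc(Cl)c4Cl)cc3)nc3[nH]ncc23)C1` likewise sits at a limit in this assay, < 1 nM. Among the measured compounds shown here, the single measured step, a step that the two limits leave unreadable from compound 1 to compound 2, is therefore unreadable, because the limit of < 1 nM in this assay, at which 2 of the 3 values shown sit, hides its size. Compound 4 `Cc1n[nH]c2nc(-c3ccc(NS(=O)(=O)c4cc(Cl)ccc4F)cc3)nc(OC3CCOCC3)c12` differs from compound 3 in one place: oxan-4-yl in place of ethyl on an oxygen on an aromatic ring. No measured step touches the oxygen group or the core of compound 3, so nothing shown speaks for a move in either direction. With only compound 3 to go on, the step expected in this assay is a 1.1-fold higher number from compound 3 to compound 4 (0.04 log units; within the scatter), within the scatter. Compound 4 is estimated at 25 nM in this assay, with a range from 8 nM to 80 nM.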

Compound 4, half-maximal inhibitory concentration: 5 nM
Compound 4: middle estimate off by 5.0-fold (0.70 log units), on the high side; measured number outside the range, below it.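

The oxygen on the aromatic ring is a place where changing the attached group moves the read-out: in this assay the step is a 4.6-fold lower number from compound 3 to compound 4 (0.66 log units; beyond the scatter) and it lies beyond the scatter. Among the compounds shown here, no earlier step touched this position, and this one shows that the core of compound 3 accepts a much larger group here, with ethoxy giving way to (oxan-4-yl)oxy, a six-membered non-aromatic ring with one hydrogen-bond acceptor, and that inhibition grows stronger rather than weaker. Nothing shown here accounts for the gain, which could come from the ring, from its oxygen or from the added size.

This single step cannot separate those possibilities. From the compounds shown here alone, what cyclohexyl, the same ring with carbon in place of its oxygen, or piperidin-4-yl, with a ring amine, would give on this oxygen remains open.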